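A few compounds are considered here, and "the series" means these few. Any claim that something is new, unique, unknown or untested is made for them only; others in the source may bear on it.

Compound 1, `CC(=O)OCc1ccc2oc(=O)c(C(=O)Oc3cccc(Cl)c3)cc2c1`, gives 49.1% in a functional assay on HT-1080 cells (Homo sapiens), read by transwell migration, with a stated time of 24 h, tested at 1 uM; on this read-out lower numbers stand for a stronger effect and higher numbers for a weaker effect at the one concentration tested.
Compound 2, `O=C(Oc1cccc(I)c1)c1cc2cc([N+](=O)[O-])ccc2oc1=O`, gives 63.6% in this assay.
Compound 3, `NCc1ccc2oc(=O)c(C(=O)Oc3cccc(Cl)c3)cc2c1`, gives 86.6% in this assay.

Compound 3 stands highest of the three numbers, which on this read-out means the weakest effect of the set. Within the data shown here, the only single-change step among the measured compounds is a number 37.5 percentage points higher from compound 1 to compound 3 (beyond the scatter), and it runs toward a weaker effect. Compound 4, `NCc1ccc2oc(=O)c(C(=O)Oc3cccc(I)c3)cc2c1`, keeps the aminomethyl group of compound 3 and differs from it only by iodo in place of chloro on an aromatic carbon. Among the measured compounds shown here, no measured step covers this swap of one halogen for another: compound 2 does carry iodo, but it differs from compound 3 in more than one place, so its value can only be set beside that of compound 3 without telling which change does what. With nothing pointing in either direction, the expected step is a number 2.6 percentage points lower from compound 3 to compound 4 (within the scatter), within the scatter, and compound 4 is estimated at 84%, with a range from 66% to 100%.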

Compound 4, a percentage reported as activity, at one concentration (the size of the read-out at that concentration, not a potency): 25.3%
Compound 4: the middle estimate sits 58.7 percentage points above what was measured, outside the stated range (below it).
By their numbers in this assay, from the lowest: compound 4; then compound 1; then compound 2; then compound 3.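

Changing 3-chlorophenyl to 3-iodophenyl in this assay is far from a minor exchange of one halogen for another: with the aminomethyl group held in place, the result is a number 61.3 percentage points lower from compound 3 to compound 4 (beyond the scatter), a shift from the weakest effect of the set to the strongest. The weak effect of compound 3 therefore cannot be pinned on aminomethyl alone, and with iodo held in place, aminomethyl in place of nitro gives a number 38.3 percentage points lower from compound 2 to compound 4 (beyond the scatter), which runs toward a stronger effect. Nothing available explains why this single halogen change matters so much.

The compounds shown leave open how bromo or fluoro on this aromatic carbon would compare with chloro and iodo. They also leave open whether iodo brings a similar change alongside the acetoxymethyl group of compound 1.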